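Replacing 3-hydroxycyclopentyl with 3-aminocyclopentyl on the shared core

The source may hold more compounds than are shown below. What is called first, only, known or untested is meant among the compounds shown, and "the series" means these compounds.

- compound 1 `Nc1ncnc2c1c(Oc1cc(C(F)(F)F)ccn1)nn2[C@@H]1CCCC[C@H]1O`: > 2.41 h (a limit)
- compound 2 `Nc1ncnc2c1c(Oc1cc(C(F)(F)F)ccn1)nn2[C@H]1C[C@H](F)C1`: 2.03 h
- compound 3 `Nc1ncnc2c1c(Oc1cc(C(F)(F)F)ccn1)nn2C1CCC(O)C1`: > 2.41 h (a limit)

These half-lives come from an ADME assay on microsomes from liver (Homo sapiens) for metabolic stability, read by LC-MS, using NADPH, with a stated time of 10 min, tested at 10 uM; a lower number here means that the compound disappears faster, a higher number that the compound lasts longer. Compound 3 stands at > 2.41 h, which is a limit and not a number.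

Compound 4 `Nc1ncnc2c1c(Oc1cc(C(F)(F)F)ccn1)nn2[C@@H]1CC[C@H](N)C1` differs from it by a single change: 3-aminocyclopentyl in place of 3-hydroxycyclopentyl on an aromatic nitrogen.

Three measured steps alter the group at this same place on an aromatic nitrogen. One is an at least 1.1-fold higher number from compound 2 to compound 3 (0.07 log units; that floor lies within the scatter), and another is an at least 1.1-fold lower number from compound 1 to compound 2 (0.07 log units; that floor lies within the scatter). The third is a step that the two limits leave unreadable from compound 1 to compound 3. Among the measured compounds shown here, no measured step exchanges 3-hydroxycyclopentyl for 3-aminocyclopentyl, so these steps serve only as a rough guide. With the readable floors of the steps involving compound 2 lying within the scatter, no step beyond the scatter is expected in this assay, and no direction is favoured.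

The expected change is a number no higher from compound 3 to compound 4 (the limit leaves the size open). For compound 4 the estimated half-life is 2.4 h, with an expected range from 1.5 h to 3.6 h.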

Compound 4, half-life: > 2.41 h
Compound 4: a limit, no number (the forecaster's own chance of this, stated with the estimate: 50%); at least 1.0-fold (0.00 log units) between middle value and limit.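

In this assay compound 4, which carries 3-aminocyclopentyl on the aromatic nitrogen, gives > 2.41 h, and this is a limit. Among the compounds shown here, a ring bearing an amine thus joins 3-hydroxycyclopentyl and 2-hydroxycyclohexyl at this position, and the one readable step is an at least 1.1-fold higher number from compound 2 to compound 4 (0.07 log units; that floor lies within the scatter). The steps joining compound 4 to compound 3 and to compound 1 cannot be read, and most of the series now shares a single limit: the limit of > 2.41 h in this assay, at which 3 of the 4 values shown sit.

Going by these compounds, how far 3-aminocyclopentyl and 3-hydroxycyclopentyl actually differ in this assay remains open. Also open, on these data alone, is whether a carboxylic acid on the cyclopentyl ring, or a longer chain on the aromatic nitrogen, would give a half-life that is a number rather than a limit.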